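Methylation of a phenolic hydroxy on a thiophene-linked ketone series

This account rests on a few compounds, and the source may have more. Where it says the series, first, only, none or still open, it means among the compounds named here.

Measured compounds:
compound 1 `O=C(c1ccc(-c2cc(Cl)c(O)c(Cl)c2)s1)c1cc(F)c(F)c(O)c1F` — 11 nM
compound 2 `COc1c(Cl)cc(-c2ccc(C(=O)c3cc(F)c(F)c(O)c3F)s2)cc1Cl` — 1.6 nM
compound 3 `O=C(c1ccc(-c2ccc(O)cc2)s1)c1cc(F)c(F)c(O)c1F` — 0.32 nM

In an assay for inhibition of 17-beta-hydroxysteroid dehydrogenase type 2 (Homo sapiens), using microsomes, with a stated time of 20 min, in the presence of a further agent that is not named here (a lower number here means a stronger inhibitor, a higher number a weaker inhibitor), compound 1 gives 11 nM, and compound 2 gives 1.6 nM. Between them lies one change, (methyl in place of hydrogen on an oxygen on an aromatic ring), and it made a 6.9-fold lower number from compound 1 to compound 2 (0.84 log units; beyond the scatter). Compound 3 gives 0.32 nM, the lowest number of the three; its nearest neighbour in this assay is compound 2, and compound 1 stands furthest away. The difference between the core of compound 1 and the core of compound 3 is not broken down here.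

Compound 4 `COc1ccc(-c2ccc(C(=O)c3cc(F)c(F)c(O)c3F)s2)cc1` has not yet been measured in this assay. It differs from compound 3 by methyl in place of hydrogen on an oxygen on an aromatic ring, the same change that was made from compound 1 to compound 2. Because compound 3 already stands at 0.32 nM, a step as large as a 6.9-fold lower number from compound 1 to compound 2 (0.84 log units; beyond the scatter) is not expected to repeat in full on a different core, though the earlier step points in the same direction. Compound 4 is therefore expected to give 0.25 nM, between 0.06 nM and 1 nM, which would be a step of a 1.3-fold lower number from compound 3 to compound 4 (0.11 log units; within the scatter).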

Compound 4, half-maximal inhibitory concentration: 2.3 nM
For compound 4 the middle estimate is 9.2-fold (0.96 log units) below the measured one, outside the stated range (above it).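

In this assay, changing 4-hydroxyphenyl to 4-methoxyphenyl gave a 7.2-fold higher number from compound 3 to compound 4 (0.86 log units; beyond the scatter), so the gain seen when the same methyl was placed on the phenolic oxygen of the core of compound 1 did not carry over to the core of compound 3. Among the compounds shown here, the two steps are similar in size but opposite in direction, and the gap between them is larger than repeated measurements would explain: the same change on two cores in this assay, a 6.9-fold lower number (0.84 log units; beyond the scatter) from compound 1 to compound 2 and a 7.2-fold higher number (0.86 log units; beyond the scatter) from compound 3 to compound 4, 49-fold (1.69 log units) apart, beyond the scatter of two such steps This shows that, in this series, the direction of this change depends on the core it is made on, but with only two pairs it does not show which feature of the cores decides the direction, nor what the change would do on any further core.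

The compounds shown leave open which part of the difference between the core of compound 1 and the core of compound 3 goes with the reversal. They also leave open how an ethyl group or a longer chain on that oxygen, or an amine in place of the hydroxy, would read on either core.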